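Inverting one ring stereocentre of compound 3

The source may report more compounds than this note shows. Statements on the series, on what has been measured and on what is new or still open speak of the compounds shown alone.

In a functional assay on EC9706 cells (Homo sapiens) for antiproliferative activity, read by MTT assay, with a stated time of 48 h (a higher number here means a weaker inhibitor, a lower number a stronger inhibitor), compound 1 (`CCCCCCCCCCCCn1cc(COC[C@@H]2OC[C@H](N)[C@@H]2O)nn1`) gives 16000 nM, compound 2 (`CCCCCCCCCCCCCCn1cc(COC[C@@H]2OC[C@H](N)[C@@H]2O)nn1`) gives 7830 nM and compound 3 (`CCCCCCCCCCCCCCCCn1cc(COC[C@@H]2OC[C@H](N)[C@@H]2O)nn1`) gives 20000 nM. Compound 3 carries the highest number, but it stays within the scatter of its nearest neighbour, a 1.3-fold higher number from compound 1 to compound 3 (0.10 log units; within the scatter), and clear of the other, a 2.6-fold higher number from compound 2 to compound 3 (0.41 log units; beyond the scatter).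

Compound 4 (`CCCCCCCCCCCCCCCCn1cc(COC[C@@H]2OC[C@H](N)[C@H]2O)nn1`) changes only configuration: the two compounds have the same atoms and bonds and differ only in configuration as drawn: 1 of 3 stereo elements differ; a stereocentre at a saturated ring carbon is drawn S in compound 3 and R in compound 4. The measured steps all alter the saturated chain, the other being a 2.0-fold lower number from compound 1 to compound 2 (0.31 log units; beyond the scatter), so none tests ring configuration. Within the data shown here, their modest size is the only guide, and no direction can be argued.

The estimated step, a 1.1-fold lower number from compound 3 to compound 4 (0.05 log units; within the scatter), is therefore expected to stay within the scatter. For compound 4 the expected value is 18000 nM, with an estimated range of 7000 nM to 45000 nM.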

Compound 4, half-maximal inhibitory concentration: 6310 nM
For compound 4 the middle estimate is 2.9-fold (0.46 log units) above the measured one; the measured number lies below the stated range.
By their numbers in this assay, from the lowest: compounds 4 and 2 (each within the scatter of the next); then compounds 1 and 3 (each within the scatter of the next).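

The saturated ring carbon is a position where configuration alone moves the number in this assay, with the R form lower: a 3.2-fold lower number from compound 3 to compound 4 (0.50 log units; beyond the scatter). Among these compounds, the earlier compounds varied only the saturated chain, so this is the first reading on the ring. The step can be assigned to this one stereocentre because nothing else changes: the fact that compounds 3 and 4 differ only in the configuration as drawn

The inversion is shown on one chain only, so its effect with the shorter chains of compound 1 and compound 2 stays open. Also open, going by these compounds, is what a methyl ether in place of the ring hydroxyl would do.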